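The source may hold more compounds than are shown below. What is called first, only, known or untested is meant among the compounds shown, and "the series" means these compounds.

Four compounds are compared in a functional assay on HT-1080 cells (Homo sapiens) for antiproliferative activity, read by sulforhodamine B assay, with a stated time of 48 h; a lower number here means a stronger inhibitor, a higher number a weaker inhibitor. Compound 1 `CCC(=O)Nc1cccc(S(=O)(=O)Oc2ccccc2C(C)C)c1` gives 12000 nM, and compound 2 `CCCC(=O)Nc1cccc(S(=O)(=O)Oc2ccccc2C(C)C)c1` gives 15000 nM. The change between them, (methyl in place of hydrogen on a saturated chain carbon, two bonds along the chain from a carbonyl carbon), made a 1.3-fold higher number from compound 1 to compound 2 (0.10 log units; within the scatter). Compound 3 `CC(C)C(=O)Nc1ccc(S(=O)(=O)Oc2ccccc2C(C)C)cc1` rests on a different core; how the two cores differ is not broken down here. In this assay compound 3 gives 4900 nM. Compound 4 `CC(C)c1ccccc1OS(=O)(=O)c1ccc(NC(=O)C(C)(C)C)cc1` has not yet been tested. Its change from compound 3, (methyl in place of hydrogen on a saturated chain carbon bound to a carbonyl carbon and two saturated chain carbons), is the same kind of change as the earlier one, though here the carbon carrying the new methyl is bound to a carbonyl carbon and two saturated chain carbons rather than two bonds along the chain from a carbonyl carbon. The earlier step, a 1.3-fold higher number from compound 1 to compound 2 (0.10 log units; within the scatter), supports an expected 1.2-fold higher number from compound 3 to compound 4 (0.09 log units; within the scatter). Compound 4 is therefore estimated at 6000 nM, with a likely range from 3000 nM to 13000 nM.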

Compound 4, half-maximal inhibitory concentration: 11000 nM
Estimate against measurement, compound 4: 1.8-fold (0.26 log units) below; the measured number falls inside the stated range.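

Changing (isopropylcarbonyl)amino to ((tert-butyl)carbonyl)amino made a 2.2-fold higher number from compound 3 to compound 4 (0.35 log units; beyond the scatter) in this assay. Set beside the earlier step, this result does not separate the two cores: the same change on two cores in this assay, a 1.3-fold higher number (0.10 log units; within the scatter) from compound 1 to compound 2 and a 2.2-fold higher number (0.35 log units; beyond the scatter) from compound 3 to compound 4, 1.8-fold (0.25 log units) apart, within the scatter of two such steps These two pairs therefore give no reason to treat the added methyl as behaving differently on the two cores, but they do not prove that it behaves the same, since each core offers only one pair and the earlier step alone lies within the scatter.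

On these data alone, it remains open whether a tert-butyl group would give a similar step on the core of compound 1. As far as these compounds go, how a longer chain, a carboxylic acid or an amine in place of the tert-butyl would fare also remains open.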